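Hydroxyphenyl placement in a weakly active diol series

This account rests on a few compounds, and the source may have more. Where it says the series, first, only, none or still open, it means among the compounds named here.

Measured so far:
compound 1 `Oc1cccc(-c2cc(-c3ccccc3F)cc(-c3ccccc3O)n2)c1`, in a functional assay on DU-145 cells (Homo sapiens) for inhibition (a lower number here means a stronger inhibitor, a higher number a weaker inhibitor), compound 1 gives 35600 nM.
compound 2 `Oc1ccc(-c2cc(-c3ccccc3F)cc(-c3ccccc3O)n2)cc1`, in this assay compound 2 gives > 50000 nM, a limit of the assay.
compound 3 `Oc1cccc(-c2cc(-c3ccccc3OC(F)(F)F)cc(-c3ccccc3O)n2)c1`, in this assay compound 3 gives > 50000 nM, a limit of the assay.

The change 4-hydroxyphenyl in place of 3-hydroxyphenyl on an aromatic carbon gave an at least 1.4-fold higher number from compound 1 to compound 2 (0.14 log units; that floor lies within the scatter). The change trifluoromethoxy in place of fluoro on an aromatic carbon gave an at least 1.4-fold higher number from compound 1 to compound 3 (0.14 log units; that floor lies within the scatter). Going by these compounds, both steps run into (the limit of > 50000 nM in this assay, at which 2 of the 3 values shown sit), so their true size is unknown.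

Compound 4 `Oc1ccc(-c2cc(-c3ccccc3OC(F)(F)F)cc(-c3ccccc3O)n2)cc1` is not yet measured. It differs from compound 3 by 4-hydroxyphenyl in place of 3-hydroxyphenyl on an aromatic carbon, the same kind of change as from compound 1 to compound 2, but at a place that is meta to a 2-hydroxyphenyl group and meta to a large group rather than meta to a 2-fluorophenyl group and meta to a 2-hydroxyphenyl group. Since compound 3 already sits at a limit, the expected step is a step that the limit leaves unreadable from compound 3 to compound 4, most likely ending again at a limit. Compound 4 is estimated at 90000 nM, with a range from 40000 nM to 300000 nM.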

Compound 4, half-maximal inhibitory concentration: 4190 nM
For compound 4 the middle estimate is 21-fold (1.33 log units) above the measured one; the whole stated range lies above it.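

In this assay, 4-hydroxyphenyl in place of 3-hydroxyphenyl gave an at least 11-fold lower number from compound 3 to compound 4 (1.07 log units; beyond the scatter), so this change does not carry over from the core of compound 1 to the core of compound 3: the same change on two cores in this assay, an at least 1.4-fold higher number (0.14 log units; that floor lies within the scatter) from compound 1 to compound 2 and an at least 11-fold lower number (1.07 log units; beyond the scatter) from compound 3 to compound 4, at least 16-fold (1.22 log units) apart, beyond the scatter of two such steps

Trifluoromethoxy in place of fluoro gave an at least 11-fold lower number from compound 2 to compound 4 (1.07 log units; beyond the scatter), and this change likewise depends on the core: the same change on two cores in this assay, an at least 1.4-fold higher number (0.14 log units; that floor lies within the scatter) from compound 1 to compound 3 and an at least 11-fold lower number (1.07 log units; beyond the scatter) from compound 2 to compound 4, at least 16-fold (1.22 log units) apart, beyond the scatter of two such steps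

Only floors can be read for these steps, not their true sizes, and a single pair of cores sets no rule for the series: the limit of > 50000 nM in this assay, at which 2 of the 4 values shown sit.

Still open, going by these compounds, is whether the activity of compound 4 survives with an amine or a carboxylic acid in place of the hydroxyl of its 4-hydroxyphenyl group.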